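A bromo in place of methoxy, awaiting its number

A few compounds are considered here, and "the series" means these few. Any claim that something is new, unique, unknown or untested is made for them only; others in the source may bear on it.

Going by the values given here, in an ADME assay on cells (Macrophage) for cytotoxicity, read by resazurin assay, with a stated time of 48 h (on this read-out lower numbers stand for higher toxicity in this test and higher numbers for lower toxicity in this test), compound 1 (`Nc1nc(-c2ccc(Cl)cc2)cc(-c2ccc(OCc3cn(Cc4ccccc4)nn3)cc2O)n1`) gives 66600 nM and so far holds the only number. Compound 2 (`CCCCCCn1cc(COc2ccc(C(=O)/C=C/c3ccc(OC)cc3)c(O)c2)nn1`) has no place on that scale: in this assay compound 2 stands as "not determined" (no result reported) with no single number behind it. Compound 3 (`CCCCCCn1cc(COc2ccc(C(=O)/C=C/c3ccc(Br)cc3)c(O)c2)nn1`) has bromo in place of methoxy on an aromatic carbon, para to a large group (bromo in place of methoxy on an aromatic carbon), and has yet to be measured. Among the compounds with values here, no measured step exists to show what such a change does here, and without a number for compound 2 no step can be read from it. The expectation in this assay is therefore a step of none beyond the scatter, with no direction assigned. The estimate rests on compound 1 (66600 nM) as the sole available anchor and stays wide. Compound 3 is expected near 45000 nM within an estimated range of 14000 nM to 140000 nM in this test.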

Compound 3, half-maximal cytotoxic concentration: > 100000 nM
Compound 3 gave a limit, no number; the forecaster's own chance of this, stated with the estimate: 20%; at least 2.2-fold (0.34 log units) between middle value and limit.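

No step can be read between compound 2 and compound 3. In this assay compound 2 has no number. Compound 3 gives > 100000 nM as a limit and not a number. The compounds shown leave open what bromo in place of methoxy does in this assay in this series.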